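The source may report more compounds than this note shows. Statements on the series, on what has been measured and on what is new or still open speak of the compounds shown alone.

Compound 1 `COc1ccc(-c2cc(-c3ccc(S(C)(=O)=O)cc3)cnc2N)cn1` is one of two compounds with a number in hand. In an ADME assay (liver) for metabolic stability, with Liver microsome (Homo sapiens) as the target, read by LC-MS, using microsomes (a higher number here means that the compound lasts longer, a lower number that the compound disappears faster), compound 1 gives 4.68 h. Its companion, compound 2 `COc1ccc(-c2nc(-c3ccc(S(C)(=O)=O)cc3)cnc2N)cn1`, gives 2.57 h in this assay. Within the data shown here, of these two numbers the one for compound 1 is the higher, yet the gap to compound 2 lies within the usual scatter of such measurements, so the two compounds cannot be separated on these data.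

The account now turns to compound 3 `CCOc1ncc(-c2ccc(S(C)(=O)=O)cc2)cc1-c1ccc(OC)nc1`, which has not yet been measured in this assay. It differs from compound 1 in one place: ethoxy in place of amino on an aromatic carbon.

Among the measured compounds shown here, no pair of measured compounds shows a change of this kind, so there is nothing in the present numbers that fixes the direction of the step. The expectation is therefore a modest step, not clearly beyond the scatter, expected as a 1.2-fold lower number from compound 1 to compound 3 (0.07 log units; within the scatter). Taking the value of compound 1, 4.68 h, as the anchor, compound 3 is estimated to give 4 h in this assay, with a range from 1.5 h to 10 h.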

Compound 3, half-life in the Liver microsome assay: 2.03 h
Compound 3: middle estimate off by 2.0-fold (0.29 log units), on the high side; low and high end bracket the measured number.
By their numbers in the Liver microsome assay, from the lowest: compounds 3, 2 and 1 (each within the scatter of the next, the first and the last beyond it).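

Among these compounds, in the Liver microsome assay, the change on the aromatic carbon next to the ring nitrogen gives the first step that stands clear of the scatter: a 2.3-fold lower number from compound 1 to compound 3 (0.36 log units; beyond the scatter). In a physicochemical assay for lipophilicity, read by HPLC, at pH 7.4 (a higher number here means a more lipophilic compound, a lower number a more polar compound), compound 1 gives 2.2 and compound 3 gives 3.7, so the same exchange also shifts this second read-out, and by a large step. Ethoxy in place of amino at this position thus makes the compound more lipophilic, and the shorter half-life may go with that rise, although a single pair cannot settle the link: the measured distribution coefficient of compound 1, 2.2, and of compound 3, 3.7, a number 1.50 log units higher (beyond the scatter).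

The compounds shown leave open whether the lower half-life follows the loss of the amino group or the arrival of the ethoxy group, and a methoxy or a methylamino group on this same carbon would help to tell these apart. Also open, going by these compounds, is whether ethoxy in place of amino would give a step of the same direction and size on the core of compound 2, and whether a longer chain or a cyclic ether here would take the half-life further down.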